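This account rests on a few compounds, and the source may have more. Where it says the series, first, only, none or still open, it means among the compounds named here.

Compound 1 `CN(C)c1ccc(C2CC(c3ccc(-n4ccnc4)cc3)=NN2)cc1` is the parent, and in a functional assay on HCC1806 cells (Homo sapiens) for inhibition, read by sulforhodamine B assay, tested at 10 uM (a lower number here means less inhibition, a higher number more inhibition at the concentration tested (going by the name of the read-out)), compound 1 gives -20.9%. Compound 2 `CN(C)c1ccc(C2CC(c3ccc(-n4ccnc4)cc3)=NN2C(=O)CCCl)cc1` carries a (2-chloroethyl)carbonyl on the ring nitrogen where compound 1 has hydrogen, and in this assay compound 2 gives -5.2%. Among the compounds with values here, the one step measured so far is a number 15.7 percentage points higher from compound 1 to compound 2 (beyond the scatter), so compound 2 stands highest of the two numbers, with compound 1 the only neighbour and lower by that step. Compound 3 `C=C(C)C(=O)N1N=C(c2ccc(-n3ccnc3)cc2)CC1c1ccc(N(C)C)cc1` differs from compound 2 by 1-methylethenyl in place of 2-chloroethyl on a carbonyl carbon. Within the data shown here, no measured step exchanges one group for another on this carbonyl carbon; the only step known changes a different place, from hydrogen to the whole (2-chloroethyl)carbonyl, and was modest. With nothing directly comparable, the expectation for this assay is a step of about a number 5.2 percentage points higher from compound 2 to compound 3 (within the scatter), not beyond the scatter. Compound 3 is therefore estimated at 0%, within a range from -20% to 20%.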

Compound 3, a percentage reported as inhibition, at one concentration (the size of the read-out at that concentration, not a potency): 1.6%
Compound 3: middle estimate off by 1.6 percentage points, on the low side; measured number inside the range.
By their numbers in this assay, from the lowest: compound 1; then compounds 2 and 3 (each within the scatter of the next).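

Placing 1-methylethenyl on the carbonyl carbon instead of 2-chloroethyl gives a number 6.8 percentage points higher from compound 2 to compound 3 (within the scatter) in this assay, so these two groups cannot be told apart here, and the chlorine is not needed to keep the number where compound 2 has it. Measured against the parent, (1-methylethenyl)carbonyl in place of hydrogen on the amine nitrogen in a ring gives a number 22.5 percentage points higher from compound 1 to compound 3 (beyond the scatter), so a second carbonyl group also stands clear of compound 1. Nothing available explains these numbers. Still open, from the compounds shown here alone, is how much the group on the carbonyl carbon can matter, since a longer chain or an amine there could behave quite differently. Whether any such group brings clear inhibition in this assay also remains unanswered.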